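This account rests on a few compounds, and the source may have more. Where it says the series, first, only, none or still open, it means among the compounds named here.

Among the measured compounds shown here, in a functional assay on HepG2 cells (Homo sapiens) for inhibition, read by MTT assay, with a stated time of 24 h (on this read-out lower numbers stand for stronger inhibition of growth and higher numbers for weaker inhibition of growth), compound 1 `Cn1cc(-c2nc3ccccc3n2C(=O)c2ccccc2)c2ccccc21` gives 42300 nM, the higher of the two numbers so far, and compound 2 `COc1ccc(C(=O)n2c(-c3cn(C)c4ccccc34)nc3ccccc32)cc1OC` gives 8400 nM. Compound 3 `COc1ccc2c(c1)c(-c1nc3ccccc3n1C(=O)c1ccccc1)cn2C` differs from compound 1 by methoxy in place of hydrogen on an aromatic carbon. For the measured compounds named here, the one measured step, a 5.0-fold lower number from compound 1 to compound 2 (0.70 log units; beyond the scatter), also brings in methoxy, but at another place, so it offers only indirect guidance. A smaller move in the same direction is therefore expected, an estimated 2.1-fold lower number from compound 1 to compound 3 (0.33 log units; beyond the scatter). For compound 3 the estimated value is 20000 nM, within an expected range of 8000 nM to 50000 nM.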

Compound 3, concentration for 50% growth inhibition: 37900 nM
The estimate for compound 3 lay 1.9-fold (0.28 log units) below the measured number; low and high end bracket the measured number.
By their numbers in this assay, from the lowest: compound 2; then compounds 3 and 1 (each within the scatter of the next).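

In this assay methoxy in place of hydrogen on the six-membered aromatic ring of carbon only gives a 1.1-fold lower number from compound 1 to compound 3 (0.05 log units; within the scatter) and so leaves the number where it was. The 3,4-dimethoxyphenyl change on the carbonyl carbon gave a 5.0-fold lower number from compound 1 to compound 2 (0.70 log units; beyond the scatter) by contrast, so in this pair of changes a methoxy group does not act alike at both places. Nothing measured here explains that contrast. On these data alone, whether a hydroxyl or an amine at this same position would move the number remains open. So does the outcome for methoxy on the other carbons of this ring.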